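Cyano for chloro: rat volume of distribution

The source may report more compounds than this note shows. Statements on the series, on what has been measured and on what is new or still open speak of the compounds shown alone.

Measured so far:
compound 1 `O=C(Nc1cccnc1-c1cccc(Cl)c1)N1CCN2C(=O)N([C@H]3C[C@@H]3c3ccccc3)C(=O)[C@@H]2C1` — 4.1 L/kg
compound 2 `N#Cc1cc(Cl)c(NC(=O)N2CCN3C(=O)N([C@H]4C[C@@H]4c4ccccc4)C(=O)[C@@H]3C2)c(Cl)c1` — 0.5 L/kg

In an in vivo ADME assay on the whole organism for pharmacokinetics, with Rattus norvegicus as the target (on this read-out lower numbers stand for narrower distribution and higher numbers for wider distribution into tissues), compound 1 gives 4.1 L/kg, the higher of the two numbers, and compound 2 gives 0.5 L/kg, a gap beyond the scatter. Compound 3 `N#Cc1cccc(-c2ncccc2NC(=O)N2CCN3C(=O)N([C@H]4C[C@@H]4c4ccccc4)C(=O)[C@@H]3C2)c1` differs from compound 1 by cyano in place of chloro on an aromatic carbon. Among the compounds with values here, no step between measured compounds isolates this change; compound 2 also carries a cyano, but it differs from compound 1 in more than one place, so its value is only an indication. A modest downward step is expected, a 2.1-fold lower number from compound 1 to compound 3 (0.31 log units; beyond the scatter), near the edge of the scatter. Compound 3 is estimated at 2 L/kg, range 0.8 L/kg to 5 L/kg.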

Compound 3, volume of distribution at steady state: 6 L/kg
Beside the measured number, compound 3's estimate is 3.0-fold (0.48 log units) below it; measured number above the stated range.
By their numbers in this assay, from the lowest: compound 2; then compounds 1 and 3 (each within the scatter of the next).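

In this assay the change from 3-chlorophenyl to 3-cyanophenyl gives a 1.5-fold higher number from compound 1 to compound 3 (0.17 log units; within the scatter) and so, in this one pair, leaves the read-out unresolved from that of the chloro compound. Within the data shown here, this is the first single-place comparison at this position, and it shows that cyano here is compatible with a value in the same range as compound 1. No measurement on hand bears on why the two values match. As far as these compounds go, whether an amine or a carboxylic acid at this position would shift the read-out beyond the scatter stays open. Also open, from the compounds shown here alone, is whether cyano in place of chloro behaves alike elsewhere on the shared core.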